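A few compounds are considered here, and "the series" means these few. Any claim that something is new, unique, unknown or untested is made for them only; others in the source may bear on it.

Measured compounds:
- compound 1, `CC(O)(C(=O)Nc1ccc(S(=O)(=O)c2ccccc2)c(O)c1)C(F)(F)F`: 430 nM
- compound 2, `COc1cc(NC(=O)C(C)(O)C(F)(F)F)ccc1S(=O)(=O)c1ccccc1`: 5900 nM
- compound 3, `CC(O)(C(=O)Nc1ccc(S(=O)(=O)c2ccccc2)c(C(F)(F)F)c1)C(F)(F)F`: > 30000 nM

The value shown for compound 3 is a limit of the assay, not a number. In a functional assay (Cavia porcellus) with sulfonylurea receptors; K-ATP channels (Homo sapiens) as the target (a lower number here means a stronger inhibitor, a higher number a weaker inhibitor), compound 1 stands lowest of the two numbers, with compound 2 the nearest.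

All three measured compounds share one core and differ only in the group on the ring that carries the amide. Swapping there cost potency each time: a 14-fold higher number from compound 1 to compound 2 (1.14 log units; beyond the scatter), an at least 69-fold higher number from compound 1 to compound 3 (1.84 log units; beyond the scatter) and an at least 5.0-fold higher number from compound 2 to compound 3 (0.70 log units; beyond the scatter). Compound 4, `CC(O)(C(=O)Nc1ccc(S(=O)(=O)c2ccncc2)c(O)c1)C(F)(F)F`, keeps the hydroxy of compound 1 and instead changes the other ring: pyridin-4-yl in place of phenyl on a sulfonyl sulfur.

Among the measured compounds shown here, none of the measured steps touches the ring on the sulfonyl sulfur, so they give no direct guide to this change; they only show that the hydroxy kept in compound 4 is the favourable choice. Compound 4 is therefore expected to stay close to compound 1, with a small loss allowed for, a 1.6-fold higher number from compound 1 to compound 4 (0.21 log units; within the scatter). The estimate for compound 4 is 700 nM, within 200 nM to 3000 nM.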

Compound 4, half-maximal inhibitory concentration: 1300 nM
The estimate for compound 4 lay 1.9-fold (0.27 log units) below the measured number; measured number inside the range.
By their numbers in this assay, from the lowest: compound 1; then compound 4; then compound 2. At a limit, above all of these: compound 3.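

The ring on the sulfonyl sulfur matters in this assay: pyridin-4-yl in place of phenyl gives a 3.0-fold higher number from compound 1 to compound 4 (0.48 log units; beyond the scatter). Among the compounds shown here, none of the earlier steps touched this ring, and this one shows that replacing a single ring carbon with a nitrogen, with the number of heavy atoms unchanged, is enough to move the result beyond the usual scatter, though the hydroxy stays in place. Nothing shown here accounts for this loss of potency.

Going by these compounds, it remains open whether pyridin-3-yl or cyclohexyl on the sulfonyl sulfur would behave like phenyl or like pyridin-4-yl. On these data alone, it is also open how an amine in place of the hydroxy would fare, and whether pyridin-4-yl would produce a similar step alongside the methoxy of compound 2.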